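The source may hold more compounds than are shown below. What is called first, only, known or untested is meant among the compounds shown, and "the series" means these compounds.

Working notes on the butyl-benzofuranyl ketone series measured in a functional assay on HL-60 cells (Homo sapiens) for antiproliferative activity, read by MTT assay, with a stated time of 24 h; a lower number here means a stronger inhibitor, a higher number a weaker inhibitor.

Compound 1, `CCCCc1oc2ccccc2c1C(=O)c1ccc(OCC(N)=O)cc1`, carries an unsubstituted amide. In this assay compound 1 reaches only a limit, > 50000 nM, so no number is available for it. Compound 2, `CCCCc1oc2ccccc2c1C(=O)c1ccc(OCC(=O)NC(C)C)cc1`, carries isopropyl on the amide-type nitrogen; in this assay compound 2 gives 360 nM. Going by the values given here, the single measured step is an at least 130-fold lower number from compound 1 to compound 2 (2.14 log units; beyond the scatter); its lower end rests on a limit, as recorded in the limit of > 50000 nM in this assay, at which 1 of the 2 values shown sits, so only a floor for its size is known. Among the compounds with values here, compound 2 therefore stands as the only compound with a number in this assay, the other value being a limit.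

Compound 3, `CCCCc1oc2ccccc2c1C(=O)c1ccc(OCC(=O)NCc2ccccc2)cc1`, differs from compound 2 by benzyl in place of isopropyl on an amide-type nitrogen. Within the data shown here, no measured step compares two substituted amides with one another, so the single step from compound 1 to compound 2 tells only that a substituent on the amide-type nitrogen matters, not how benzyl and isopropyl compare. The expectation is therefore a step of a 1.2-fold lower number from compound 2 to compound 3 (0.08 log units; within the scatter), within the scatter. For compound 3 the estimate in this assay is 300 nM, with a range from 90 nM to 1200 nM.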

Compound 3, half-maximal inhibitory concentration: > 50000 nM
Compound 3 was reported as a limit (the forecaster's own chance of this, stated with the estimate: 5%); middle value at least 160-fold (2.22 log units) from the limit.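

Benzyl and isopropyl are not interchangeable on the amide-type nitrogen: in this assay there is an at least 130-fold higher number from compound 2 to compound 3 (2.14 log units; beyond the scatter), and this size is only a floor. The earlier step showed that a substituent on this nitrogen can matter, whereas this result shows that carrying a substituent is not enough, since benzyl, with its six-membered aromatic ring of carbon only, does not give a measured number here. Isopropyl is therefore the only group on this nitrogen with a number, while the hydrogen and benzyl compounds both rest at a limit, so the step between compound 1 and compound 3 cannot be read: the limit of > 50000 nM in this assay, at which 2 of the 3 values shown sit.

As far as these compounds go, with a number for only one substituent, no trend on the amide-type nitrogen can be drawn, and it remains open how groups between or beyond these two would read, such as ethyl, cyclopropyl, tert-butyl or phenyl. Also open, from the compounds shown here alone, is whether a chain ending in a dimethylamino group or a carboxylic acid on this nitrogen would give a number in this assay, or whether the butyl chain on the shared core could be changed with the isopropyl amide kept.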